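Fluoro in place of nitro: expected potency of compound 4

The source may report more compounds than this note shows. Statements on the series, on what has been measured and on what is new or still open speak of the compounds shown alone.

Measured so far:
compound 1 `C/C(=N\NC(=S)Nc1cccc([N+](=O)[O-])c1)c1ccccn1` gives 38 nM in a functional assay on MCF7 cells (Homo sapiens) for cytotoxicity, read by MTT assay, with a stated time of 48 h; a higher number here means a weaker inhibitor, a lower number a stronger inhibitor
compound 2 `C/C(=N/NC(=S)Nc1cccc([N+](=O)[O-])c1)c1ccccn1` gives 38 nM
compound 3 `CC(=NNC(=S)Nc1cccc([N+](=O)[O-])c1)c1ccccn1` gives 38 nM

Compound 1 stands level with compounds 2 and 3 in this assay. The step of no change at the digits printed from compound 1 to compound 2 (within the scatter) is accompanied by the fact that compounds 1 and 2 differ only in the configuration as drawn; the step of no change at the digits printed from compound 1 to compound 3 (within the scatter) by the fact that one of compounds 1 and 3 is drawn with a defined configuration and the other without, at the place where they differ; and the step of no change at the digits printed from compound 2 to compound 3 (within the scatter) by the fact that one of compounds 2 and 3 is drawn with a defined configuration and the other without, at the place where they differ. Compound 4 `C/C(=N\NC(=S)Nc1cccc(F)c1)c1ccccn1` is not yet measured; it differs from compound 1 by fluoro in place of nitro on an aromatic carbon. Within the data shown here, none of the measured steps touches the substituent on that ring, so they give no direct guide to this change, and with all three values level no step beyond the scatter has been seen. For compound 4 the expected step in this assay is a 1.6-fold higher number from compound 1 to compound 4 (0.20 log units; within the scatter), a small shift at most, direction uncertain. Compound 4 is therefore estimated at 60 nM, within 12 nM to 300 nM.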

Compound 4, half-maximal inhibitory concentration: 9 nM
Compound 4: the middle estimate sits 6.7-fold (0.82 log units) above what was measured; measured number below the stated range.
By their numbers in this assay, from the lowest: compound 4; then compounds 1, 2 and 3 (each within the scatter of the next).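

In this assay, among these compounds, fluoro in place of nitro on an aromatic carbon gives a 4.2-fold lower number from compound 1 to compound 4 (0.63 log units; beyond the scatter), the first step beyond the scatter. The substituent on this ring therefore moves the number, which the configuration changes among compounds 1, 2 and 3 did not do, and nitro is not needed to reach this level. Nothing available bears on the reason for this step.

On these data alone, whether an amine, a methoxy group or plain hydrogen on the same carbon would follow fluoro remains open. So does whether compound 4 would stay level with its double bond drawn in the other configuration, as the nitro compounds do.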